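From trifluoromethyl to fluoro: the step to compound 4

A few compounds are considered here, and "the series" means these few. Any claim that something is new, unique, unknown or untested is made for them only; others in the source may bear on it.

Of the compounds shown here, three sharing one core have been measured in a functional assay on RT-112 cells (Homo sapiens) for antiproliferative activity, read by MTT assay, with a stated time of 72 h; on this read-out higher numbers stand for weaker inhibition of growth and lower numbers for stronger inhibition of growth. Compound 1 `COc1cc(Nc2ncnc3c(NC(=O)Nc4ccc(F)cc4C(F)(F)F)cccc23)cc(OC)c1` gives 2970 nM. Compound 3 `COc1cc(Nc2ncnc3c(NC(=O)Nc4cccc(Cc5ccccc5)c4)cccc23)cc(OC)c1` gives 1740 nM, which lies within the usual scatter of the value for compound 1. Compound 2 `COc1cc(Nc2ncnc3c(NC(=O)Nc4cc(C(F)(F)F)cc(C(F)(F)F)c4)cccc23)cc(OC)c1` gives 467 nM, a number lower than that of compound 1 by more than the scatter. Compound 1 therefore stands level with compound 3 and clearly apart from compound 2.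

The unmeasured compound 4 `COc1cc(Nc2ncnc3c(NC(=O)Nc4ccc(F)cc4F)cccc23)cc(OC)c1` keeps the core of compound 1 and carries fluoro in place of trifluoromethyl on an aromatic carbon, ortho to a large group and meta to a fluoro group. This turns 4-fluoro-2-(trifluoromethyl)phenyl into 2,4-difluorophenyl (fluoro in place of trifluoromethyl on an aromatic carbon).

Going by the values given here, no pair of measured compounds differs in one place only, so the data give no direct size for this change. The expectation therefore rests on compound 1 at 2970 nM, and no step beyond the scatter is expected in this assay. The estimate amounts to an expected step of a 1.1-fold higher number from compound 1 to compound 4 (0.03 log units; within the scatter). For compound 4 the estimated value is 3200 nM, with an expected range of 1300 nM to 8000 nM.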

Compound 4, concentration for 50% growth inhibition: 2460 nM
For compound 4 the middle estimate is 1.3-fold (0.11 log units) above the measured one; low and high end bracket the measured number.
By their numbers in this assay, from the lowest: compound 2; then compounds 3, 4 and 1 (each within the scatter of the next).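

In this assay, going by these compounds alone, the exchange of trifluoromethyl for fluoro gives the first direct reading of a single change at this position: a 1.2-fold lower number from compound 1 to compound 4 (0.08 log units; within the scatter). On the shared core, 4-fluoro-2-(trifluoromethyl)phenyl and 2,4-difluorophenyl therefore cannot be told apart on this read-out, even though the group that leaves has 4 heavy atoms and the group that enters has 1. Nothing at hand explains this lack of a measurable difference, so it stands as a bare observation.

The compounds shown leave open whether the same result would hold for other groups at this position, such as hydrogen, a methoxy group, an amine or a carboxylic acid. They also leave open what the fluoro group shared by compound 1 and compound 4 contributes to the number, a question that only a pair differing at that place alone could answer.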